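Propoxy to ethoxy on the shared core

The source may hold more compounds than are shown below. What is called first, only, known or untested is meant among the compounds shown, and "the series" means these compounds.

Three compounds of this series have numbers in an assay on HEK293 cells for inhibition of potassium channel subfamily T member 1 (Homo sapiens), read by thallium flux; a higher number here means a weaker inhibitor, a lower number a stronger inhibitor. Compound 1 `CCCOc1ccc(Cl)cc1NC(=O)CN1CCN(S(=O)(=O)N2CCC(C)CC2)CC1` gives 4300 nM, the highest of the three. Compound 2 `COc1ccc(Cl)cc1NC(=O)CN1CCN(S(=O)(=O)N2CCC(C)CC2)C[C@H]1C` gives 2400 nM, a number within the scatter of compound 1. Compound 3 `COc1ccc(Cl)cc1NC(=O)CN1CCN(S(=O)(=O)N2CCN(S(=O)(=O)c3ccccc3)CC2)CC1` gives 1100 nM, and the gap between compound 3 and compound 1 lies beyond the scatter.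

Compound 4 `CCOc1ccc(Cl)cc1NC(=O)CN1CCN(S(=O)(=O)N2CCC(C)CC2)CC1` is not yet measured. It differs from compound 1 by hydrogen in place of methyl on a saturated chain carbon, two bonds along the chain from an oxygen on an aromatic ring, read one bond further out as propoxy to ethoxy. No measured pair isolates this change, so the direction rests on no shown step. The expected step is a 1.4-fold lower number from compound 1 to compound 4 (0.16 log units; within the scatter), a lean toward a lower number that stays within the scatter. Compound 4 is estimated to give 3000 nM, with a range from 1200 nM to 7500 nM.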

Compound 4, half-maximal inhibitory concentration: 7100 nM
For compound 4 the middle estimate is 2.4-fold (0.37 log units) below the measured one; low and high end bracket the measured number.
By their numbers in this assay, from the lowest: compound 3; then compounds 2, 1 and 4 (each within the scatter of the next, the first and the last beyond it).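

In this assay, for the compounds shown here, the change from propoxy to ethoxy on the shared core gives a 1.7-fold higher number from compound 1 to compound 4 (0.22 log units; within the scatter), the first pair that differs in one place. At this position, the two chains cannot be told apart by this measurement. Nothing shown bears on the reason for this result.

Open, from the compounds shown here alone, is whether a longer chain such as butoxy, or a branched one such as isopropoxy, would move the number beyond the scatter. Also open, going by these compounds, is whether the same change reads alike on other cores.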